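Cytotoxicity notes on a methoxy-to-amino swap

The source may report more compounds than this note shows. Statements on the series, on what has been measured and on what is new or still open speak of the compounds shown alone.

Compound 1 `COc1cc(OC)cc(-c2cc3ccccc3c(-c3cccc(OC)c3)n2)c1` and compound 2 `COc1cc(OC)cc(-c2cc3ccccc3c(-c3cccc(N)c3)n2)c1` share a core and differ by amino in place of methoxy on an aromatic carbon. In an ADME assay on MCF-10A cells (Homo sapiens) for cytotoxicity, read by CCK-8 assay and cell counting, with a stated time of 72 h (on this read-out higher numbers stand for weaker inhibition and lower numbers for stronger inhibition), compound 1 gives > 50000 nM, which is a limit of the assay. Compound 2 likewise reaches only a limit, > 50000 nM. The step that the two limits leave unreadable from compound 1 to compound 2 therefore cannot be sized, as both readings sit at the limit of > 50000 nM in this assay, at which 3 of the 3 values shown sit. Compound 3 `COc1cccc(-c2nc(-c3ccc(OC)c(OC)c3)cc3cc(C)ccc23)c1` carries a different core; the difference between the two cores is not broken down here. In this assay compound 3 gives > 50000 nM, again a limit. Compound 4 `COc1ccc(-c2cc3cc(C)ccc3c(-c3cccc(N)c3)n2)cc1OC` is not yet measured; it differs from compound 3 by amino in place of methoxy on an aromatic carbon, the same change as from compound 1 to compound 2. Since compound 3 stands at the limit of > 50000 nM in this assay, at which 3 of the 3 values shown sit, and the same change left compound 2 at the limit, compound 4 is expected to remain at the limit as well, an estimated step that the limit leaves unreadable from compound 3 to compound 4. The estimate for compound 4 is 60000 nM.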

Compound 4, half-maximal inhibitory concentration: 5600 nM
Compound 4: middle estimate off by 11-fold (1.03 log units), on the high side; the measured number lies below the stated range.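

In this assay the change from 3-methoxyphenyl to 3-aminophenyl gives an at least 8.9-fold lower number from compound 3 to compound 4 (0.95 log units; beyond the scatter) on the core of compound 3. Compound 3 reads only as a limit, so this size is a floor and the true step may be larger. The same change on the core of compound 1 cannot be read, so the step is not shown to carry from one core to the other, and the part of the core that matters is not shown either: the limit of > 50000 nM in this assay, at which 3 of the 4 values shown sit.

Open, as far as these compounds go, is whether a hydroxyl or a methylamino group in the same place gives a readable step on the core of compound 3. Also open, from the compounds shown here alone, is whether either group moves the core of compound 1 off its limit.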